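From 5-chloro-2-methoxyphenyl to 5-fluoro-2-methylphenyl

This account rests on a few compounds, and the source may have more. Where it says the series, first, only, none or still open, it means among the compounds named here.

In an in vitro ADME assay on microsomes from Gut (Homo sapiens) for metabolic stability, in the presence of a further agent that is not named here (a lower number here means slower removal, a higher number faster removal of the compound), compound 1 (`COc1ccc(Cl)cc1Cn1c(C(=O)NCC(C)(C)CO)cc2cc(C#N)ccc21`) gives 63 mL.min-1.g-1 and compound 2 (`COc1ccc(Cl)cc1Cn1c(C(=O)NCC2(CO)CCC2)cc2cc(C#N)ccc21`) gives 179 mL.min-1.g-1 as the higher of the two numbers. Compound 3 (`Cc1ccc(F)cc1Cn1c(C(=O)NCC2(CO)CCC2)cc2cc(C#N)ccc21`) has not yet been measured. Compared with compound 2, it carries 5-fluoro-2-methylphenyl in place of 5-chloro-2-methoxyphenyl on a saturated chain carbon bound to an aromatic nitrogen. Among the compounds with values here, only one measured step is available, and it is a modest one: a 2.8-fold higher number from compound 1 to compound 2 (0.45 log units; beyond the scatter) when 1-(hydroxymethyl)cyclobutyl replaces 1-(hydroxymethyl)-1-methylethyl on a saturated chain carbon bound to an amide-type nitrogen. That step lies at a different place, so it bears only indirectly on the new change. Within the data shown here, no measured pair tests a change on the carbon bound to the aromatic nitrogen, and the data give no direction. The expected change is therefore small, with an estimated 1.1-fold lower number from compound 2 to compound 3 (0.05 log units; within the scatter) and nothing beyond the scatter anticipated. For compound 3 the expected value is 160 mL.min-1.g-1 with an estimated range of 70 mL.min-1.g-1 to 350 mL.min-1.g-1 on the same read-out.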

Compound 3, intrinsic clearance in microsomes: 175 mL.min-1.g-1
Compound 3: middle estimate off by 1.1-fold (0.04 log units), on the low side, and the stated range covers the measured number.
By their numbers in this assay, from the lowest: compound 1; then compounds 3 and 2 (each within the scatter of the next).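

In this assay, within the data shown here, the first measured change on the saturated chain carbon bound to an aromatic nitrogen gives no step beyond the scatter (a 1.0-fold lower number from compound 2 to compound 3 (0.01 log units; within the scatter)). Among these compounds, this holds even though 5-fluoro-2-methylphenyl has one hydrogen-bond acceptor fewer than 5-chloro-2-methoxyphenyl and carries fluorine and no oxygen, so on this cyclobutyl-bearing amide side chain the exchange of these two aryl groups is not read out as a difference in intrinsic clearance, and the only step beyond the scatter among the three compounds remains the one on the amide side (a 2.8-fold higher number from compound 1 to compound 2 (0.45 log units; beyond the scatter)). No measurement given here accounts for this result.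

From the compounds shown here alone, both ring substituents change together in this single pair, so the contribution of each cannot be separated, and it remains unknown whether the two aryl groups would also match with 1-(hydroxymethyl)-1-methylethyl on the amide side. Going by these compounds, it is also open whether a more different group at this place, such as a benzyl ring bearing a carboxylic acid or an amine, would shift the number beyond the scatter.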